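A Carboxamide Becomes an Acid on a Limit-Bound Scaffold

The source may report more compounds than this note shows. Statements on the series, on what has been measured and on what is new or still open speak of the compounds shown alone.

Compound 1 `NC(=O)CCCCN(Cc1cccc(C(N)=O)c1)C[C@H]1O[C@@H](n2cnc3c(N)ncnc32)[C@H](O)[C@@H]1O` in an assay on cells for inhibition of Nicotinamide N-methyltransferase (Homo sapiens), with stated times of 10 min and 30 min (a higher number here means a weaker inhibitor, a lower number a stronger inhibitor), gives > 250000 nM, which is a limit of the assay and not a number.
Compound 2 `NC(=O)c1cccc(CN(CCCCC(=O)O)C[C@H]2O[C@@H](n3cnc4c(N)ncnc43)[C@H](O)[C@@H]2O)c1` in this assay gives > 250000 nM, also a limit.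
Compound 3 `CC(C)N(Cc1cccc(C(N)=O)c1)C[C@H]1O[C@@H](n2cnc3c(N)ncnc32)[C@H](O)[C@@H]1O` in this assay gives > 250000 nM, again a limit.

Compound 2 therefore stands only at a limit, as do the other two, all three sitting together at the limit of > 250000 nM in this assay, at which 3 of the 3 values shown sit. Compound 4 `Nc1ncnc2c1ncn2[C@@H]1O[C@H](CN(CCCCC(=O)O)Cc2cccc(C(=O)O)c2)[C@@H](O)[C@H]1O` differs from compound 2 by hydroxy in place of amino on a carbonyl carbon. Of the measured steps, a step that the two limits leave unreadable from compound 1 to compound 2 concerns the same exchange on another carbonyl carbon, while a step that the two limits leave unreadable from compound 1 to compound 3 and a step that the two limits leave unreadable from compound 2 to compound 3 alter the amine nitrogen; none has a readable size. The step expected in this assay, a step that the limit leaves unreadable from compound 2 to compound 4, is accordingly estimated as no change beyond the scatter. Compound 4 is expected to give 300000 nM, between 100000 nM and 1000000 nM, most likely again reported only as a limit.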

Compound 4, half-maximal inhibitory concentration: > 250000 nM
Compound 4: only a limit was reported (the forecaster's own chance of this, stated with the estimate: 85%); the middle value is on the limit's open side.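

Going by these compounds alone, compound 2 and compound 4 are both reported only as limits and not as numbers, so no step between them can be read. The compounds shown leave open whether any structure on this shared core gives a readable value in this assay at all.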